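This account rests on a few compounds, and the source may have more. Where it says the series, first, only, none or still open, it means among the compounds named here.

In a functional assay on MCF7 cells (Homo sapiens) for cytotoxicity, read by MTT assay, with a stated time of 24 h (a lower number here means a stronger inhibitor, a higher number a weaker inhibitor), compound 1 `O=C1/C(=C/c2ccccc2F)CN(C(=S)SCc2cn(Cc3ccccc3Cl)nn2)C/C1=C\c1ccccc1F` gives 78700 nM as its reading, and compound 2 `O=C1/C(=C/c2ccccc2F)CN(Cc2cn(Cc3ccccc3Cl)nn2)C/C1=C\c1ccccc1F` gives 10000 nM as its reading. Compound 1 therefore holds the higher of the two numbers, which makes it the weaker inhibitor of this pair, and the gap lies beyond the usual scatter of repeat measurements. Compound 3 `O=C1/C(=C/c2ccccc2F)CN(C(=S)SCc2cn(Cc3cccc(Cl)c3)nn2)C/C1=C\c1ccccc1F` has not yet been measured in this assay and keeps everything in compound 1 except one detail. The change 3-chlorophenyl in place of 2-chlorophenyl on a saturated chain carbon bound to an aromatic nitrogen puts 3-chlorophenyl in place of 2-chlorophenyl on a saturated chain carbon bound to an aromatic nitrogen. The same atoms remain, only joined differently. For the measured compounds named here, no measured pair here shows what such a swap does, so the expectation is modest: in this assay the estimated step of a 1.3-fold lower number from compound 1 to compound 3 (0.12 log units; within the scatter) is expected to stay within the scatter, with no firm direction. For compound 3 the expected value is 60000 nM with an estimated range of 22000 nM to 150000 nM around it.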

Compound 3, half-maximal inhibitory concentration: > 100000 nM
Compound 3 gave a limit, no number; the forecaster's own chance of this, stated with the estimate: 10%; middle value at least 1.6-fold (0.22 log units) from the limit.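

In this assay compound 3 gives > 100000 nM, which is a limit of the assay and not a number. Moving the chlorine, with 3-chlorophenyl in place of 2-chlorophenyl on a saturated chain carbon bound to an aromatic nitrogen, gives an at least 1.2-fold higher number from compound 1 to compound 3 (0.10 log units; that floor lies within the scatter), so this first look at the position offers no sign of a stronger inhibitor from this change, although the printed floor alone does not separate the two compounds. The full size of the step cannot be read because the reading of compound 3 ends in a limit: the limit of > 100000 nM in this assay, at which 1 of the 3 values shown sits.

Still open, on these data alone, is whether the same swap would act in the same way in compound 2, whose shared core carries the triazole-bearing chain without the sulfur-containing link of compound 1. The compounds shown also leave open what a 4-chlorophenyl group, a plain phenyl group or a phenyl ring bearing a carboxylic acid would do at this place, and whether any of them would bring the number down.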